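The source may hold more compounds than are shown below. What is called first, only, known or untested is meant among the compounds shown, and "the series" means these compounds.

Working notes on the series in a functional assay on thoracic aorta (Rattus norvegicus, strain Wistar), with a stated time of 15 min; on this read-out higher numbers stand for an effect only at larger amounts of compound and lower numbers for an effect already at smaller amounts. Compound 1 (`COc1ccc(Br)cc1C(C)NC(=O)N(C)S(=O)(=O)c1ccc(C)cc1`) gives 19100 nM, and compound 2 (`CCOc1ccc(Br)cc1C(C)NC(=O)N(C)S(=O)(=O)c1ccc(Cl)cc1`) gives 55700 nM. Compound 2 thus holds the higher of the two numbers, and its gap to compound 1 lies beyond the usual scatter. The two compounds differ in more than one place, so that gap cannot be assigned to any single change.

Compound 3 (`COc1ccc(Br)cc1C(C)NC(=O)N(C)S(=O)(=O)c1ccc(Cl)cc1`) has not yet been measured. It differs from compound 2 by one change: hydrogen in place of methyl on a saturated chain carbon bound to an oxygen on an aromatic ring, which reads as ethoxy to methoxy.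

Within the data shown here, no measured step isolates this change, so the evidence is thin. Compound 1 also carries the methoxy group and gives 19100 nM, which points to a modest move toward lower numbers in this assay, though a step within the scatter would not be surprising. The expected change is a 2.0-fold lower number from compound 2 to compound 3 (0.30 log units; within the scatter). The estimate for compound 3 is 28000 nM, with an expected range from 12000 nM to 60000 nM.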

Compound 3, half-maximal effective concentration: 19100 nM
Compound 3: the middle estimate sits 1.5-fold (0.17 log units) above what was measured, within the range that was stated.
By their numbers in this assay, from the lowest: compounds 1 and 3 (each within the scatter of the next); then compound 2.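

In this assay the change from ethoxy to methoxy now has a measured size on its own: hydrogen in place of methyl on a saturated chain carbon bound to an oxygen on an aromatic ring gives a 2.9-fold lower number from compound 2 to compound 3 (0.46 log units; beyond the scatter) and so lies outside the scatter, although this rests on one pair only. Chloro in place of methyl on an aromatic carbon, read by itself, gives no change at the digits printed from compound 1 to compound 3 (within the scatter) and so stays within the scatter. Of the two places that separate compound 1 from compound 2, only the ethoxy to methoxy change therefore shows a step beyond the scatter, at least with chloro on the aromatic carbon. Nothing at hand accounts for either step.

From the compounds shown here alone, what a propoxy group or a free hydroxyl would give at this place remains open, so no trend with chain length can be drawn from one ethyl to methyl step. Also open, going by these compounds, is whether the ethoxy to methoxy step keeps its size with methyl rather than chloro on the aromatic carbon.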